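A Single Fluorine Swap on the Benzoyl Arm

This account rests on a few compounds, and the source may have more. Where it says the series, first, only, none or still open, it means among the compounds named here.

Two close analogues share one core and differ only in the aryl group attached to a carbonyl carbon. Compound 1 `CN(C(=O)NC(=O)c1ccc(Cl)cc1Cl)c1nc(C(F)(F)F)c(C(=O)N/N=C/c2cccc(C(F)(F)F)c2)s1` gives 10.7 ug/mL in a functional assay on MCF7 cells (Homo sapiens) for inhibition, read by MTT assay, with a stated time of 72 h (a lower number here means a stronger inhibitor, a higher number a weaker inhibitor), while compound 2 `CN(C(=O)NC(=O)c1ccc(F)c(F)c1)c1nc(C(F)(F)F)c(C(=O)N/N=C/c2cccc(C(F)(F)F)c2)s1` gives 4.15 ug/mL. Compound 2 thus holds the lowest number of the two measured, the step of a 2.6-fold lower number from compound 1 to compound 2 (0.41 log units; beyond the scatter) being modest but clear.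

Compound 3 `CN(C(=O)NC(=O)c1ccccc1F)c1nc(C(F)(F)F)c(C(=O)N/N=C/c2cccc(C(F)(F)F)c2)s1` is the next variation: 2-fluorophenyl in place of 3,4-difluorophenyl on a carbonyl carbon. For the measured compounds named here, only the step from compound 1 to compound 2 speaks to halogen changes on this ring, and it concerned a different exchange, so it guides only loosely. A move that removes one fluorine is expected to shift the number little, perhaps slightly upward, so the expected step is a 1.3-fold higher number from compound 2 to compound 3 (0.12 log units; within the scatter). Compound 3 is therefore estimated at 5.5 ug/mL, with a plausible range from 2.5 ug/mL to 12 ug/mL.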

Compound 3, half-maximal inhibitory concentration: 20.5 ug/mL
Compound 3: the middle estimate sits 3.7-fold (0.57 log units) below what was measured; measured number outside the range, above it.
By their numbers in this assay, from the lowest: compound 2; then compounds 1 and 3 (each within the scatter of the next).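

In this assay, the halogen pattern on this ring matters more than the first pair could show: 2-fluorophenyl in place of 3,4-difluorophenyl on the carbonyl carbon gives a 4.9-fold higher number from compound 2 to compound 3 (0.69 log units; beyond the scatter), so this exchange is far from silent. The 2-fluorophenyl and 2,4-dichlorophenyl groups, by contrast, are not separated, with a 1.9-fold higher number from compound 1 to compound 3 (0.28 log units; within the scatter), which leaves compound 2 alone at the low end of this small set. Nothing available here explains why the number responds to this change.

This exchange alters both the number of fluorines and the places they occupy, so the two contributions cannot be told apart. As far as these compounds go, it remains open whether a 3-fluorophenyl or 4-fluorophenyl group would keep the low number of compound 2, and how an unsubstituted phenyl or a methoxyphenyl group would compare.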